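The source may hold more compounds than are shown below. What is called first, only, known or untested is meant among the compounds shown, and "the series" means these compounds.

Of the compounds shown here, three sharing one core have been tested in a functional assay on WM1361 cells (Homo sapiens) for inhibition, read by MTT assay, with a stated time of 24 h (a lower number here means a stronger inhibitor, a higher number a weaker inhibitor), and only one of them returned a number. Compound 1 (`O=c1oc2ccccc2c(N2CCN(c3cccc(Cl)c3Cl)CC2)c1CO`) gives 45900 nM. Compound 2 (`O=c1oc2ccccc2c(N2CCN(c3ccccc3)CC2)c1CO`) reaches only a limit, > 50000 nM. Compound 3 (`O=c1oc2ccccc2c(N2CCN(c3ccc(F)cc3)CC2)c1CO`) likewise reaches only a limit, > 50000 nM.

The measured steps are therefore thin. They comprise an at least 1.0-fold higher number from compound 1 to compound 2 (0.03 log units; that floor lies within the scatter) and an at least 1.0-fold higher number from compound 1 to compound 3 (0.03 log units; that floor lies within the scatter), and neither can be sized further because of the limit of > 50000 nM in this assay, at which 2 of the 3 values shown sit. The remaining comparison is a step that the two limits leave unreadable from compound 2 to compound 3.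

Compound 4 (`O=c1oc2ccccc2c(N2CCN(c3ccc(Cl)c(Cl)c3)CC2)c1CO`) has not yet been measured. It carries 3,4-dichlorophenyl in place of 2,3-dichlorophenyl on an amine nitrogen in a ring, (3,4-dichlorophenyl in place of 2,3-dichlorophenyl on an amine nitrogen in a ring). For the measured compounds named here, no measured step exchanges one dichlorophenyl for another, so the two steps from compound 1 bear on this change only indirectly, and neither shows a change beyond the scatter.

With compound 1 at 45900 nM as the only anchor, no step beyond the scatter is expected in this assay, in either direction. A result reported only as a limit would be no surprise. The expected change is a 1.1-fold lower number from compound 1 to compound 4 (0.04 log units; within the scatter). For compound 4 the estimated value is 42000 nM, with an expected range of 18000 nM to 80000 nM.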

Compound 4, half-maximal inhibitory concentration: 42700 nM
For compound 4 the middle estimate is 1.0-fold (0.01 log units) below the measured one; low and high end bracket the measured number.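

For the compounds shown here, the first direct exchange of one dichlorophenyl for another, with the same atoms joined differently at the same place on the amine nitrogen in a ring, gives in this assay a 1.1-fold lower number from compound 1 to compound 4 (0.03 log units; within the scatter), so the assay does not separate 2,3-dichlorophenyl from 3,4-dichlorophenyl here. Compound 4 also joins compound 1 as a second dichlorophenyl compound that returns a number, while compound 2 and compound 3 remain limits, yet the comparisons give only an at least 1.1-fold lower number from compound 3 to compound 4 (0.06 log units; that floor lies within the scatter) and an at least 1.1-fold lower number from compound 2 to compound 4 (0.06 log units; that floor lies within the scatter). Neither floor can show whether chlorine substitution matters, because the phenyl and 4-fluorophenyl values stop at the top of the readable range: the limit of > 50000 nM in this assay, at which 2 of the 4 values shown sit.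

The compounds shown therefore leave open whether any group at this place can give a step beyond the scatter, whether a methoxy or trifluoromethyl group on the phenyl ring or a benzyl group in place of the aromatic ring on the nitrogen. They also leave open what a carboxylic acid or an amine elsewhere on the shared core would do.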